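The source may report more compounds than this note shows. Statements on the series, on what has been measured and on what is new or still open speak of the compounds shown alone.

Measured compounds in an ADME assay on HeLa cells (Homo sapiens) for cytotoxicity, read by sulforhodamine B assay, with a stated time of 48 h, tested at 10 uM; on this read-out lower numbers stand for less inhibition and higher numbers for more inhibition at the one concentration tested (going by the name of the read-out):

- compound 1, `CCCCCCc1cn(C(c2ccccc2)c2cc3cc(Br)ccc3nc2OC)nn1`: -0.97%
- compound 2, `COc1nc2ccc(Br)cc2cc1C(c1ccccc1)n1cc(-c2ccccc2F)nn1`: 14.1%
- compound 3, `CCCCCc1cn(C(c2ccccc2)c2cc3cc(Br)ccc3nc2OC)nn1`: -9.81%

Compound 3 gives the lowest of the three numbers in this assay. Its nearest neighbour is compound 1, where the change is a number 8.8 percentage points lower from compound 1 to compound 3 (within the scatter), a step within the scatter, so the two cannot be ranked against each other. The furthest is compound 2, reached by a number 23.9 percentage points lower from compound 2 to compound 3 (beyond the scatter), and the related step of a number 15.1 percentage points higher from compound 1 to compound 2 (beyond the scatter) points the same way: replacing an alkyl chain with 2-fluorophenyl raises the inhibition modestly.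

The next compound, compound 4, `COc1nc2ccc(Br)cc2cc1C(c1ccccc1)n1cc(CCO)nn1`, differs from compound 3 by hydroxy in place of propyl on a saturated chain carbon, two bonds along the chain from an aromatic carbon.

Among the compounds with values here, the only measured step that touches the chain itself is the one from compound 1 to compound 3, and it lay within the scatter. Within the data shown here, no measured pair introduces a hydroxy group, so there is no direct precedent for it. The two steps that exceed the scatter both involve an aromatic ring entering or leaving, which is not the case here. The step of a number 6.8 percentage points higher from compound 3 to compound 4 (within the scatter) is therefore expected to be small, with no clear direction beyond the scatter. Compound 4 is expected to give about -3% in this assay, within a range from -16% to 12%.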

Compound 4, a percentage reported as inhibition, at one concentration (the size of the read-out at that concentration, not a potency): 0.85%
Compound 4: the middle estimate sits 3.9 percentage points below what was measured; measured number inside the range.
By their numbers in this assay, from the lowest: compounds 3, 1 and 4 (each within the scatter of the next, the first and the last beyond it); then compound 2.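

In this assay, a hydroxy group on the chain at this position gives a mixed reading: a number 10.7 percentage points higher from compound 3 to compound 4 (beyond the scatter), yet a number 1.8 percentage points higher from compound 1 to compound 4 (within the scatter). The size of the change therefore depends on which alkyl chain serves as the reference, and the two alkyl compounds cannot themselves be ranked, so no firm effect of the hydroxy group can be claimed. The 2-fluorophenyl group remains apart from the 2-hydroxyethyl chain, with a number 13.3 percentage points lower from compound 2 to compound 4 (beyond the scatter), and so far it is the only substituent at this aromatic carbon whose number lies beyond the scatter of all the others; no data on the cause of these differences are available.

From the compounds shown here alone, it remains open whether an amine or a carboxylic acid in place of the hydroxy group, or a longer hydroxyalkyl chain, would separate from the alkyl compounds in this assay. Also open, going by these compounds, is whether an unsubstituted phenyl in place of 2-fluorophenyl would keep the higher number, which would show whether the ring or its fluorine goes with that reading.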